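Trimming the amide substituent of a low-toxicity thioether

This account rests on a few compounds, and the source may have more. Where it says the series, first, only, none or still open, it means among the compounds named here.

Compound 1 `CCCC(=O)OCSc1ccccc1C(=O)N[C@@H]1CCC[C@@H]1C(N)=O` was tested in an ADME assay on CEM-SS cells (Homo sapiens) for cytotoxicity, read by XTT assay, with a stated time of 6 days (on this read-out lower numbers stand for higher toxicity in this test and higher numbers for lower toxicity in this test), and gives 90 uM. Among the two compounds measured so far it stands highest, the end that marks the gentler side of this test. Among the measured compounds shown here, the only other compound measured is compound 2 `CCCC(=O)OC[Se]c1ccccc1C(=O)NCC(N)=O`, which in this assay gives 6.8 uM; the gap between these two numbers lies beyond the usual scatter, but the two structures differ in more than one place, so nothing can be read from them about any single change.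

Compound 3 `CCCC(=O)OCSc1ccccc1C(N)=O` has not yet been measured. It differs from compound 1 in one place: hydrogen in place of 2-carbamoylcyclopentyl on an amide-type nitrogen. For the measured compounds named here, no measured pair shows this change, so the step is expected to be modest, perhaps a little toward the more toxic side, and possibly no larger than the scatter. For compound 3 in this assay the expected step is a 1.5-fold lower number from compound 1 to compound 3 (0.18 log units; within the scatter). The estimate for compound 3 is therefore 60 uM, with a range from 20 uM to 150 uM.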

Compound 3, half-maximal toxic concentration: 12.4 uM
Beside the measured number, compound 3's estimate is 4.8-fold (0.68 log units) above it; the whole stated range lies above it.
By their numbers in this assay, from the lowest: compounds 2 and 3 (each within the scatter of the next); then compound 1.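

Among the compounds shown here, replacing the 2-carbamoylcyclopentyl group on the amide-type nitrogen with hydrogen is the first single change that can be read in this assay, and it gives a 7.3-fold lower number from compound 1 to compound 3 (0.86 log units; beyond the scatter). This shows that the substituent at this position matters in this test: the group present in compound 1 goes with a clearly gentler result than the bare hydrogen of compound 3. No measurement shown here explains the size of this step.

Going by these compounds, with only these two ends of the change in hand, it remains open whether the whole 2-carbamoylcyclopentyl group is needed or only part of it. On these data alone, it also remains open whether a plain cyclopentyl or a short chain such as ethyl on the same nitrogen would retain the higher number of compound 1.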